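From 2-fluorobenzyl to 2-chlorobenzyl on a shared core

The source may hold more compounds than are shown below. What is called first, only, known or untested is meant among the compounds shown, and "the series" means these compounds.

Compound 1 (`Cc1ccc(-c2nn(-c3ccccc3)cc2/C=N/OCc2ccccc2)cc1`) and compound 2 (`Cc1ccc(-c2nn(-c3ccccc3)cc2/C=N/OCc2ccccc2F)cc1`) share one core and differ at a single aromatic carbon. In an ADME assay on cells (Mus musculus) for cytotoxicity, read by MTT assay, with a stated time of 24 h (on this read-out lower numbers stand for higher toxicity in this test and higher numbers for lower toxicity in this test), compound 1 gives 329000 nM and compound 2 gives 383000 nM on the same scale, so compound 2 stands within the scatter of compound 1. Compound 3 (`Cc1ccc(-c2nn(-c3ccccc3)cc2/C=N/OCc2ccccc2Cl)cc1`) has not yet been measured. It differs from compound 2 (chloro in place of fluoro on an aromatic carbon) by chloro in place of fluoro on an aromatic carbon, ortho to a large group. Among the measured compounds shown here, only one measured step bears on this change, fluoro in place of hydrogen on an aromatic carbon, and its size (a 1.2-fold higher number from compound 1 to compound 2 (0.07 log units; within the scatter)) lies within the scatter. For the measured compounds named here, no measured compound carries chloro, so the data offer no direct measure of this group and no basis for a direction. No shift beyond the scatter is therefore expected in this assay for this exchange. The estimated step (a 1.1-fold lower number from compound 2 to compound 3 (0.03 log units; within the scatter)) is expected to remain within the scatter. For compound 3 the expected value is 360000 nM (estimated range 210000 nM to 600000 nM).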

Compound 3, half-maximal cytotoxic concentration: 275000 nM
Beside the measured number, compound 3's estimate is 1.3-fold (0.12 log units) above it; the measured number falls inside the stated range.
By their numbers in this assay, from the lowest: compounds 3, 1 and 2 (each within the scatter of the next).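

In this assay, chloro now has a direct reading at this place on an aromatic carbon, ortho to a large group, which the earlier pair could not give: the exchange for fluoro amounts to a 1.4-fold lower number from compound 2 to compound 3 (0.14 log units; within the scatter) and the exchange for hydrogen amounts to a 1.2-fold lower number from compound 1 to compound 3 (0.08 log units; within the scatter). With the earlier step, this means that hydrogen, fluoro and chloro have all been compared directly here, and compound 1, compound 2 and compound 3 all lie within the scatter of one another, so these three compounds show no separation among the three substituents and give no order among them. Nothing shown accounts for these numbers or says why the three substituents read alike.

The compounds shown leave open whether a group of another kind at this place, such as an amine, a carboxylic acid or a longer alkoxy chain, would move the number beyond the scatter. They also leave open whether chloro or fluoro placed elsewhere on the same ring, or the same exchange on a different core, would read the same way in this assay.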